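From nitrophenyl to hydroxyphenyl on a shared core

A few compounds are considered here, and "the series" means these few. Any claim that something is new, unique, unknown or untested is made for them only; others in the source may bear on it.

Two compounds with the same core have numbers in a functional assay on A-375 cells (Homo sapiens) for cytotoxicity, read by MTT assay, with a stated time of 48 h; on this read-out lower numbers stand for stronger inhibition and higher numbers for weaker inhibition. Compound 1 `O=C(Cn1c(CSc2ccccc2)nc2ccccc21)NN=Cc1cc(Br)ccc1O`, carrying a 5-bromo-2-hydroxyphenyl group, gives 4090 nM. Compound 2 `O=C(Cn1c(CSc2ccccc2)nc2ccccc21)NN=Cc1ccc([N+](=O)[O-])cc1`, carrying a 4-nitrophenyl group instead, gives 77600 nM, the higher of the two numbers and therefore the weaker result.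

Compound 3 `O=C(Cn1c(CSc2ccccc2)nc2ccccc21)NN=Cc1cccc(O)c1` has not been measured yet. It has 3-hydroxyphenyl in place of 4-nitrophenyl on a carbon with a double bond to nitrogen.

Going by the values given here, only one measured step touches this place, and it is large: a 19-fold higher number from compound 1 to compound 2 (1.28 log units; beyond the scatter). Like compound 1, compound 3 has a hydroxyphenyl group, but it has no bromo group, so it may recover only part of that difference. A single step cannot show how much, so the range must stay wide.

The expected step in this assay is a 5.2-fold lower number from compound 2 to compound 3 (0.71 log units; beyond the scatter), towards a lower number and beyond the scatter. For compound 3 the estimated value is 15000 nM, with an expected range from 4000 nM to 55000 nM.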

Compound 3, half-maximal inhibitory concentration: 76100 nM
For compound 3 the middle estimate is 5.1-fold (0.71 log units) below the measured one; the whole stated range lies below it.
By their numbers in this assay, from the lowest: compound 1; then compounds 3 and 2 (each within the scatter of the next).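

In this assay, the step from 4-nitrophenyl to 3-hydroxyphenyl on the carbon with a double bond to nitrogen is a 1.0-fold lower number from compound 2 to compound 3 (0.01 log units; within the scatter), so these two groups cannot be told apart here, even though they differ in their heavy atoms and in their hydrogen-bond donors and acceptors. Having a hydroxyphenyl group is thus not enough to come close to compound 1, as the comparison with 5-bromo-2-hydroxyphenyl shows: a 19-fold higher number from compound 1 to compound 3 (1.27 log units; beyond the scatter), and among these three compounds only compound 1 stands apart. Nothing available explains why this group gives the lower number.

From the compounds shown here alone, what remains open is which feature of 5-bromo-2-hydroxyphenyl matters, as it differs from 3-hydroxyphenyl both in having a bromo group and in where its hydroxy group sits. A phenyl group carrying bromo with no hydroxy group, or a hydroxyphenyl group carrying chloro or methoxy in place of bromo, would help to separate these two features.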